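The source may report more compounds than this note shows. Statements on the series, on what has been measured and on what is new or still open speak of the compounds shown alone.

Measured in a physicochemical assay for solubility, in phosphate buffer, measured as kinetic solubility, at pH 7.4, tested at 250 uM; on this read-out lower numbers stand for lower solubility and higher numbers for higher solubility:
- compound 1 `O=C(O)c1ccc(NCCCCCCCC(F)(F)F)c(S(=O)(=O)NC2CCCCC2)c1`: 9000 nM
- compound 2 `O=C(O)c1ccc(NCCCCCCCC(F)(F)F)c(S(=O)(=O)NC2CCOCC2)c1`: 244000 nM
- compound 3 `CN(C)S(=O)(=O)c1cc(C(=O)O)c(Cl)cc1NCCCCCCCC(F)(F)F`: 241000 nM

Compound 3 at 241000 nM lies within the scatter of compound 2 at 244000 nM. Compound 1 at 9000 nM lies far lower, well beyond the scatter.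

The next compound is compound 4 `CCOc1cc(NCCCCCCCC(F)(F)F)c(S(=O)(=O)N(C)C)cc1C(=O)O`, with ethoxy in place of chloro on an aromatic carbon, ortho to a carboxy group, meta to a large group and para to a dimethylsulfamoyl group: ethoxy in place of chloro on an aromatic carbon.

Within the data shown here, only one measured step is available, a 27-fold higher number from compound 1 to compound 2 (1.43 log units; beyond the scatter), and it is large. It swaps oxan-4-yl for cyclohexyl on a sulfonamide nitrogen, a different place from this change. It shows how far the read-out can move in this series, but gives no direction here. Among the measured compounds shown here, no measured step covers chloro or ethoxy.

The expected result in this assay is therefore no clear shift, with a slight drop at most, and the estimated step is a 1.3-fold lower number from compound 3 to compound 4 (0.13 log units; within the scatter). For compound 4 the estimate is 180000 nM, with an expected range from 70000 nM to 250000 nM.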

Compound 4, solubility: 43000 nM
Compound 4: the middle estimate sits 4.2-fold (0.62 log units) above what was measured; measured number outside the range, below it.
By their numbers in this assay, from the lowest: compound 1; then compound 4; then compounds 3 and 2 (each within the scatter of the next).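

In this assay this aromatic carbon, ortho to a carboxy group and para to a dimethylsulfamoyl group, proves sensitive to substitution: ethoxy in place of chloro gives a 5.6-fold lower number from compound 3 to compound 4 (0.75 log units; beyond the scatter), a step beyond the scatter. The read-out in this series therefore moves with a group on the aromatic ring as well as with one on a sulfonamide nitrogen, although this step is modest beside the large 27-fold higher number from compound 1 to compound 2 (1.43 log units; beyond the scatter). No measurement available here accounts for the drop.

On these data alone, whether the drop belongs to ethoxy alone or extends to other groups on this carbon stays open, and methoxy, hydroxy or an amine there would help to settle it. Also open, as far as these compounds go, is whether the same change gives a similar step with oxan-4-yl on the sulfonamide nitrogen.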